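The source may hold more compounds than are shown below. What is called first, only, known or untested is meant among the compounds shown, and "the series" means these compounds.

Series measured in a functional assay on A-431 cells (Homo sapiens) for antiproliferative activity, read by MTT assay, with a stated time of 48 h; a lower number here means a stronger inhibitor, a higher number a weaker inhibitor:
- compound 1 `O=C(CCCCCC(=O)Nc1ccc(O)c(C(=O)Nc2ccc(F)c(F)c2)c1)NO`: 4010 nM
- compound 2 `O=C(CCCCCC(=O)Nc1ccc(O)c(C(=O)Nc2ccc(F)c(Cl)c2)c1)NO`: 3480 nM
- compound 3 `C#Cc1cccc(NC(=O)c2cc(NC(=O)CCCCCC(=O)NO)ccc2O)c1`: 5750 nM

Compound 3 cannot be separated from the other two on these numbers. The a 1.4-fold higher number from compound 1 to compound 3 (0.16 log units; within the scatter) and a 1.7-fold higher number from compound 2 to compound 3 (0.22 log units; within the scatter) both stay within the scatter.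

Next in the series is compound 4 `O=C(CCCCCC(=O)Nc1ccc(O)c(C(=O)Nc2ccc(Cl)c(Cl)c2)c1)NO`, with 3,4-dichlorophenyl in place of 3-ethynylphenyl on an amide-type nitrogen.

Going by the values given here, three measured steps bear on this change. The two above replace the group on the same nitrogen, and neither moves this assay beyond the scatter. The a 1.2-fold lower number from compound 1 to compound 2 (0.06 log units; within the scatter) is the only chloro in place of fluoro step, and it is also within the scatter. Among the compounds with values here, no measured compound yet carries 3,4-dichlorophenyl, so these steps give only indirect support. No step beyond the scatter is therefore expected, with at most a slight drift towards the values of compound 1 and compound 2.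

The expected change is a 1.6-fold lower number from compound 3 to compound 4 (0.19 log units; within the scatter).

For compound 4 the estimate is 3700 nM, with an expected range of 1900 nM to 7000 nM.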

Compound 4, half-maximal inhibitory concentration: 3800 nM
The estimate for compound 4 lay 1.0-fold (0.01 log units) below the measured number; the range from low to high includes it.
By their numbers in this assay, from the lowest: compounds 2, 4, 1 and 3 (each within the scatter of the next).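

In this assay, placing a 3,4-dichlorophenyl on the amide-type nitrogen gives no separation from the 3-ethynylphenyl group (a 1.5-fold lower number from compound 3 to compound 4 (0.18 log units; within the scatter)). The second chloro in place of fluoro step (a 1.1-fold higher number from compound 2 to compound 4 (0.04 log units; within the scatter)) agrees with the first (a 1.2-fold lower number from compound 1 to compound 2 (0.06 log units; within the scatter)), and exchanging one dihalogenated ring for the other also leaves the compounds unseparated (a 1.1-fold lower number from compound 1 to compound 4 (0.02 log units; within the scatter)). All four groups at this position now fall within the scatter of one another, and no measurement is available to explain this flat result.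

Whether this position can move the number beyond the scatter remains open, since every group shown is a substituted phenyl without hydrogen-bond donors or acceptors. An unsubstituted phenyl, or a phenyl carrying an amine or a carboxylic acid, would test this, while a longer chain on the shared core would probe a different part of the series.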